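The source may report more compounds than this note shows. Statements on the series, on what has been measured and on what is new or still open speak of the compounds shown alone.

Compound 1 `Cc1cccc(Oc2ccnc(N3CCC[C@H]3C(=O)NCCCn3ccnc3)n2)c1` gives 0% in an assay on isolated protein for inhibition of vascular endothelial growth factor receptor 1 (Homo sapiens), read by HTRF, tested at 10 uM; a higher number here means more inhibition at the concentration tested (going by the name of the read-out), a lower number less inhibition.
Compound 2 `Clc1ccc2sc(CN3CCN(c4ncnc5c4CN(Cc4ccccc4)CC5)CC3)cc2c1` gives 0% in this assay.
Compound 3 `O=C(CN1CCN(c2ncnc3c2CN(Cc2ccccc2)CC3)CC1)Nc1cc(F)ccc1F` gives 0% in this assay.

Compound 2 stands level with compound 1 and compound 3 at the digits reported; none of the three shows any inhibition in this assay, and the nearest and furthest of its neighbours are within the scatter of it.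

Compound 4 `Cc1cc(C(=O)N2CCN(c3ncnc4c3CN(Cc3ccccc3)CC4)CC2)c(C)n1C` has not yet been measured. It differs from compound 2 in one place: (1,2,5-trimethyl-1H-pyrrol-3-yl)carbonyl in place of (5-chloro-1-benzothiophen-2-yl)methyl on an amine nitrogen in a ring.

Within the data shown here, only one measured step bears on this change, and it also replaces the group on the same ring nitrogen of the shared core of compound 2 by a carbonyl-bearing group: no change at the digits printed from compound 2 to compound 3 (within the scatter). That step was flat, and all three measured compounds sit at the floor of the read-out. There is no case among them of any substituent on that nitrogen lifting inhibition, so no step beyond the scatter is expected in this assay from the exchange leading to compound 4, and the step is estimated as no change at the digits printed from compound 2 to compound 4 (within the scatter). Compound 4 is therefore expected to give 0%, in the range -5% to 10%.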

Compound 4, a percentage reported as inhibition, at one concentration (the size of the read-out at that concentration, not a potency): 0%
Estimate against measurement, compound 4: no gap at the digits printed; low and high end bracket the measured number.
By their numbers in this assay, from the lowest: compounds 1, 2, 3 and 4 (each within the scatter of the next).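

In this assay, the exchange at this amine nitrogen in a ring gives no change at the digits printed from compound 2 to compound 4 (within the scatter), so a carbonyl bound directly to that nitrogen, carrying a five-membered aromatic ring alone, leaves the read-out where (5-chloro-1-benzothiophen-2-yl)methyl left it. The earlier step, no change at the digits printed from compound 2 to compound 3 (within the scatter), had kept a saturated chain carbon on the nitrogen, so this result extends the flat picture to a group attached through a carbonyl. No measurement offered here explains the absence of inhibition at this position.

All the compounds shown sit level in this assay, so none of them ranks one group on this nitrogen over another. From the compounds shown here alone, whether a sulfonyl group, or a longer chain ending in an amine or a carboxylic acid, would give any inhibition remains open.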